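The source may hold more compounds than are shown below. What is called first, only, known or untested is meant among the compounds shown, and "the series" means these compounds.

Compounds measured in a functional assay on NCI-H226 cells (Homo sapiens) for cytotoxicity, read by sulforhodamine B assay, with a stated time of 48 h; a lower number here means a stronger inhibitor of growth, a higher number a weaker inhibitor of growth:
compound 1 `ClCc1ccccc1Cn1cnc2c(Cl)nc(Cl)nc21` — 1730 nM
compound 2 `ClCc1ccccc1Cn1cnc2c(Cl)ncnc21` — 4570 nM
compound 3 `ClCc1cccc(Cn2cnc3ncnc(Cl)c32)c1` — 3160 nM

Compound 2 gives the highest number of the three in this assay. Its gap to compound 3 lies within the scatter, so the two are not separable; the step of a 2.6-fold higher number from compound 1 to compound 2 (0.42 log units; beyond the scatter) is beyond the scatter and modest. Among the compounds with values here, that is the only single-site step measured in the set.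

Compound 4 `Nc1nc(Cl)c2ncn(Cc3ccccc3CCl)c2n1` is not yet measured. It differs from compound 2 by amino in place of hydrogen on an aromatic carbon. Within the data shown here, no measured step bears on it directly: the one step known, a 2.6-fold higher number from compound 1 to compound 2 (0.42 log units; beyond the scatter), concerns the same site but exchanges chloro for hydrogen, and the set holds no amino analogue. Among the measured compounds shown here, the only guide is that a substituent at this site has once shifted the number by a modest amount, and that filling the site again may move the number back toward the value seen for compound 1 . A small step of a 1.5-fold lower number from compound 2 to compound 4 (0.18 log units; within the scatter) toward a lower number is therefore expected, of a size that may not clear the scatter. Compound 4 is estimated at 3000 nM, with a range from 1000 nM to 9000 nM.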

Compound 4, concentration for 50% growth inhibition: 2630 nM
Compound 4: the middle estimate sits 1.1-fold (0.06 log units) above what was measured; the measured number falls inside the stated range.
By their numbers in this assay, from the lowest: compounds 1, 4, 3 and 2 (each within the scatter of the next, the first and the last beyond it).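

In this assay, amino on the aromatic carbon between two ring nitrogen atoms gives a 1.7-fold lower number from compound 2 to compound 4 (0.24 log units; within the scatter) and, measured against the chloro group at the same site, a 1.5-fold higher number from compound 1 to compound 4 (0.18 log units; within the scatter). Both steps lie within the scatter, so compound 4 cannot be separated from compound 2 or from compound 1, even though those two are separable from each other; the site accepts amino, but this change adds no readable shift to the single one seen with chloro. No measured evidence on hand accounts for these numbers.

As far as these compounds go, whether a larger group at this site, such as dimethylamino or methoxy, gives a step beyond the scatter remains open. Also open, from the compounds shown here alone, is whether amino reads the same with the chloromethyl group placed as in compound 3, or with hydroxymethyl in place of chloromethyl.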